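Swapping chloro for methoxy on the aryl side arm

The source may hold more compounds than are shown below. What is called first, only, known or untested is meant among the compounds shown, and "the series" means these compounds.

Compound 1 `OCC(O)Cn1nc2c(Br)c(Br)c(Br)c(Br)c2n1`: 53%
Compound 2 `C[C@@H](O)CCn1nc2c(Br)c(Br)c(Br)c(Br)c2n1`: 18%
Compound 3 `OC(CCn1nc2c(Br)c(Br)c(Br)c(Br)c2n1)c1cccc(Cl)c1`: 0%

In a functional assay on MCF7 cells (Homo sapiens) for antiproliferative activity, read by MTT assay, with a stated time of 24 h, tested at 100 uM (on this read-out higher numbers stand for a weaker effect at the one concentration tested and lower numbers for a stronger effect), compound 3 gives the lowest number of the three, the strongest effect, with compound 2 coming nearest. For the measured compounds named here, the one step measured so far, a number 35 percentage points lower from compound 1 to compound 2 (beyond the scatter), concerns the chain on the nitrogen rather than the aryl group, so it bears only indirectly on the move to compound 4 `COc1cccc(C(O)CCn2nc3c(Br)c(Br)c(Br)c(Br)c3n2)c1`, where (methoxy in place of chloro on an aromatic carbon). Going by the values given here, no measured step tests a change on that aryl ring. Compound 3 sits already at the floor of this assay, so little room remains downward; a small rise, or none beyond the scatter, is expected, and the step of a number 8 percentage points higher from compound 3 to compound 4 (within the scatter) is estimated as modest. Compound 4 is expected to give 8%, within 0% to 30%.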

Compound 4, a percentage reported as activity, at one concentration (the size of the read-out at that concentration, not a potency): 16%
Compound 4: middle estimate off by 8 percentage points, on the low side, and the stated range covers the measured number.
By their numbers in this assay, from the lowest: compound 3; then compounds 4 and 2 (each within the scatter of the next); then compound 1.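

In this assay, for the compounds shown here, the aryl ring is changed for the first time, and the change is not silent: a number 16 percentage points higher from compound 3 to compound 4 (beyond the scatter). So the group on this aromatic carbon matters, and of the two, 3-chlorophenyl gives the stronger effect, although methoxy still leaves a low number. Nothing available explains why the two groups differ. As far as these compounds go, it remains open where a methyl, a fluoro or an amino group in the same place would fall relative to chloro and methoxy. A plain phenyl ring with no group on it is also an open case.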